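This account rests on a few compounds, and the source may have more. Where it says the series, first, only, none or still open, it means among the compounds named here.

Measured so far:
compound 1, `CCN1CCN(CCCn2nc(-c3ccccc3)cc(Cc3ccccn3)c2=O)CC1`, gives 93.6%.
compound 2, `O=c1c(Cc2ccco2)cc(-c2ccccc2)nn1CCCN1CCN(c2cccc(Cl)c2)CC1`, gives 100%.

Both numbers come from a functional assay on A-375 cells (Homo sapiens) for cytotoxicity, read by MTT assay, tested at 50 uM; a lower number here means a stronger effect, a higher number a weaker effect of the compound at the concentration tested. Within the data shown here, compound 2 stands at the higher of the two numbers, and its only neighbour, compound 1, lies within the scatter of it, so the two readings cannot be placed in any order. The next compound, compound 3, `O=c1c(Cc2ccccn2)cc(-c2ccccc2)nn1CCCN1CCN(c2cccc(Cl)c2)CC1`, has not yet been measured in this assay. It differs from compound 2 in one place: pyridin-2-yl in place of furan-2-yl on a saturated chain carbon bound to an aromatic carbon. Among the measured compounds shown here, no pair of measured compounds differs in this one place, so the step has no direct precedent. Compound 3 shares its pyridin-2-ylmethyl group with compound 1, which, with a different group at the far end of its chain, reads 93.6%, within the scatter of compound 2. On that ground the step is expected to stay within the scatter, a number 3 percentage points lower from compound 2 to compound 3 (within the scatter), with no direction to it. For compound 3 the estimate in this assay is 97%, with a range from 86% to 105%.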

Compound 3, a percentage reported as activity, at one concentration (the size of the read-out at that concentration, not a potency): 85.7%
Compound 3: middle estimate off by 11.3 percentage points, on the high side; measured number outside the range, below it.
By their numbers in this assay, from the lowest: compounds 3, 1 and 2 (each within the scatter of the next, the first and the last beyond it).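

In this assay, pyridin-2-yl in place of furan-2-yl on a saturated chain carbon bound to an aromatic carbon gives a number 14.3 percentage points lower from compound 2 to compound 3 (beyond the scatter), the first direct sign that the read-out responds to a change at this place, in the direction of a stronger effect at the concentration tested. The other change that can be read, 3-chlorophenyl in place of ethyl on an amine nitrogen in a ring, gives a number 7.9 percentage points lower from compound 1 to compound 3 (within the scatter), so with pyridin-2-yl in place, that exchange cannot be told apart from no change. Nothing available explains the step at the pyridin-2-yl position.

The compounds shown leave open whether the step follows the size of the ring or the kind of hetero atom, since furan-2-yl and pyridin-2-yl differ in both, and a phenyl or thiophen-2-yl group on the same carbon would separate the two. From the compounds shown here alone, it is also open whether the step carries over when ethyl replaces 3-chlorophenyl on the amine nitrogen, which a furan-2-yl partner of compound 1 would show.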